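The source may hold more compounds than are shown below. What is called first, only, known or untested is meant among the compounds shown, and "the series" means these compounds.

Compound 1 `N#Cc1c(Nc2ccc(N)cc2)sc2ccccc12`: 51%
Compound 2 `N#Cc1c(Nc2ccc(O)cc2)sc2ccccc12`: 2%
Compound 3 `CC(=O)N(c1ccc(O)cc1)c1sc2ccccc2c1C#N`: 59%

In a functional assay on HUVEC cells (Homo sapiens), read by fluorescence and microscopy, with a stated time of 6 h, tested at 250 nM (a higher number here means a weaker effect of the compound at the concentration tested, a lower number a stronger effect), compound 2 stands lowest of the three measured compounds, with compound 1 nearest and compound 3 furthest from it. Both measured steps are large: a number 49 percentage points lower from compound 1 to compound 2 (beyond the scatter), and a number 57 percentage points higher from compound 2 to compound 3 (beyond the scatter). Compound 4 `N#Cc1c(Nc2ccc([N+](=O)[O-])cc2)sc2ccccc12` differs from compound 2 in one place: nitro in place of hydroxy on an aromatic carbon. The step from compound 1 to compound 2 bears most directly on this change, since it also exchanged the group at the same place, and it moved the number a long way. A large step upward from compound 2 is therefore expected, with a number 43 percentage points higher from compound 2 to compound 4 (beyond the scatter). Compound 4 is estimated to give 45%, in a range from 10% to 85%.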

Compound 4, a percentage reported as activity, at one concentration (the size of the read-out at that concentration, not a potency): 37%
For compound 4 the middle estimate is 8 percentage points above the measured one, within the range that was stated.
By their numbers in this assay, from the lowest: compound 2; then compound 4; then compounds 1 and 3 (each within the scatter of the next).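

In this assay, nitro gives up much of what hydroxy achieves at this place, para to a large group, with a number 35 percentage points higher from compound 2 to compound 4 (beyond the scatter) and a large step. Nitro and amino also differ from each other, with a number 14 percentage points lower from compound 1 to compound 4 (beyond the scatter) in a modest step beyond the scatter, so the two replacements of hydroxy are not equivalent and the three groups give three separate levels. Nothing measured here accounts for these differences. Open, going by these compounds, is whether methoxy or a carboxylic acid at this place would stay close to compound 2 or fall nearer compound 4.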